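A few compounds are considered here, and "the series" means these few. Any claim that something is new, unique, unknown or untested is made for them only; others in the source may bear on it.

In a functional assay on the whole organism (strain albino) for inhibition, with Rattus norvegicus as the target, read by paw edema, with stated times of 30 min and 5 h, at a dose of 0.28 mmol/kg by the oral route (a lower number here means less inhibition, a higher number more inhibition at the dose given (going by the name of the read-out)), three compounds have been measured so far. Compound 2 `C=CCn1c(SCC(=O)Nc2ccc(/C(C)=N/O)cc2)nnc1-c1ccccc1` gives 71%. Compound 1 `C=CCn1c(SCC(=O)Nc2ccc(C(C)=O)cc2)nnc1-c1ccccc1` differs from compound 2 in that (a group of 3 heavy atoms (2 carbon, 1 oxygen; no ring) in place of a group of 4 heavy atoms (2 carbon, 1 nitrogen, 1 oxygen; no ring), on an aromatic carbon). Compound 1 gives 63%; that change made the step of a number 8 percentage points lower from compound 2 to compound 1 (within the scatter). Compound 3 `CCn1c(SCC(=O)Nc2ccc(/C(C)=N/O)cc2)nnc1-c1ccccc1` gives 66%. Its core differs from the core of compound 2 in that (methyl in place of vinyl on a saturated chain carbon bound to an aromatic nitrogen), and that change made the step of a number 5 percentage points lower from compound 2 to compound 3 (within the scatter). All three values sit close together, so the numbers are level and none can be called higher than the others.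

Compound 4 `CCn1c(SCC(=O)Nc2ccc(C(C)=O)cc2)nnc1-c1ccccc1` has not yet been measured. It differs from compound 3 in that (a group of 3 heavy atoms (2 carbon, 1 oxygen; no ring) in place of a group of 4 heavy atoms (2 carbon, 1 nitrogen, 1 oxygen; no ring), on an aromatic carbon). This is the same change that turns compound 2 into compound 1, now made on the core of compound 3 instead. Resting on the measured step of a number 8 percentage points lower from compound 2 to compound 1 (within the scatter), the step expected here is a number 7 percentage points lower from compound 3 to compound 4 (within the scatter), a small downward shift that stays within the usual scatter. In this assay compound 4 is therefore estimated at 59%, with a likely range from 47% to 70%.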

Compound 4, a percentage reported as inhibition, in the whole organism at one dose (the size of the read-out at that dose, not a potency): 66%
The estimate for compound 4 lay 7 percentage points below the measured number; the range from low to high includes it.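

Putting acetyl in place of the group of 4 heavy atoms on the core of compound 3 gives no change at the digits printed from compound 3 to compound 4 (within the scatter) in this assay, and this step does not differ from the same change on the other core: the same change on two cores in this assay, a number 8 percentage points lower (within the scatter) from compound 2 to compound 1 and no change at the digits printed (within the scatter) from compound 3 to compound 4, 8 percentage points apart, within the scatter of two such steps

The second change, methyl in place of vinyl, gives a number 3 percentage points higher from compound 1 to compound 4 (within the scatter), and it too does not differ between the two cores: the same change on two cores in this assay, a number 5 percentage points lower (within the scatter) from compound 2 to compound 3 and a number 3 percentage points higher (within the scatter) from compound 1 to compound 4, 8 percentage points apart, within the scatter of two such steps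

So on these two cores, neither change has a step that stands out from the usual scatter, but this does not show that the steps are truly identical, nor that they would hold on any other core.

The compounds shown leave open what a longer chain would do in place of that methyl, or what an amine or a carboxylic acid would do in place of acetyl. With all four compounds read at a single dose, they also leave open how their potencies compare.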